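The source may hold more compounds than are shown below. What is called first, only, known or untested is meant among the compounds shown, and "the series" means these compounds.

Measured so far in a functional assay on ES2 cells (Homo sapiens) for cytotoxicity, read by MTT assay, with a stated time of 48 h; on this read-out lower numbers stand for stronger inhibition and higher numbers for weaker inhibition
- compound 1 `O=C(CN1C(=O)C2(OCCCCO2)c2cc(Cl)ccc21)NO` gives 212000 nM
- compound 2 `O=C(CN1C(=O)C2(OCCCCO2)c2cc(F)ccc21)NO` gives 553000 nM

Compound 2 holds the higher of the two numbers, so it is the weaker of this pair. Next in line is compound 3 `O=C(CN1C(=O)C2(OCCCCO2)c2cc(Br)ccc21)NO` with bromo in place of fluoro on an aromatic carbon and the change is bromo in place of fluoro on an aromatic carbon. Within the data shown here, only one measured step bears on this: a 2.6-fold higher number from compound 1 to compound 2 (0.42 log units; beyond the scatter) is a modest move, and it is fluoro in place of chloro on an aromatic carbon. Among the measured compounds shown here, no bromo compound has been measured yet, and a single step between two compounds sets no firm trend. Even so, leaving fluoro for a heavier halogen runs opposite to that step, so a modest move to a lower number is expected in this assay of about the same size. The estimated step is a 2.8-fold lower number from compound 2 to compound 3 (0.44 log units; beyond the scatter) and this remains an expectation only. The estimate for compound 3 is 200000 nM with an expected range from 90000 nM to 450000 nM on this read-out.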

Compound 3, half-maximal inhibitory concentration: 409000 nM
Beside the measured number, compound 3's estimate is 2.0-fold (0.31 log units) below it, within the range that was stated.
By their numbers in this assay, from the lowest: compounds 1, 3 and 2 (each within the scatter of the next, the first and the last beyond it).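

In this assay, bromo in place of fluoro on an aromatic carbon gives a 1.4-fold lower number from compound 2 to compound 3 (0.13 log units; within the scatter) and bromo in place of chloro at the same carbon gives a 1.9-fold higher number from compound 1 to compound 3 (0.29 log units; within the scatter) so compound 3 cannot be separated from either halogen neighbour on this read-out. The earlier step, a 2.6-fold higher number from compound 1 to compound 2 (0.42 log units; beyond the scatter) thus remains the only separation in the set, and it does not extend to an order across all three halogens: compound 3 sits within the scatter of both compounds, while only compound 1 and compound 2 stand apart. No measurement on hand accounts for the values at this position, so the halogen series can only be described here and not explained.

The compounds shown leave open what this aromatic carbon would give with a hydrogen, a methoxy group, a nitrile or an amine, since every substituent so far is a single halogen atom. They also leave open how far the values would move with a carboxylic acid in place of the hydroxamic acid end, or with a longer chain between that end and the shared core.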